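Replacing morpholin-4-yl on the carbonyl carbon

This account rests on a few compounds, and the source may have more. Where it says the series, first, only, none or still open, it means among the compounds named here.

Compound 1 `CCCN(C)C(=O)Cn1c(-c2ccc(Cl)cc2)nc2cccnc21` and compound 2 `O=C(Cn1c(-c2ccc(Cl)cc2)nc2cccnc21)N1CCOCC1` share one core and differ only in the group on a carbonyl carbon. In a functional assay on the whole organism with Mus musculus as the target (a lower number here means that less compound is needed, a higher number that more compound is needed for the effect), compound 1 gives 11.6 mg/kg and compound 2 gives 11.5 mg/kg, so compound 2 stands level with compound 1. Compound 3 `O=C(Cn1c(-c2ccc(Cl)cc2)nc2cccnc21)Nc1cccnc1` changes that same place, with (pyridin-3-yl)amino in place of morpholin-4-yl on a carbonyl carbon.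

Within the data shown here, only one measured step bears on this place. That step, a 1.0-fold lower number from compound 1 to compound 2 (0.00 log units; within the scatter), stayed within the scatter. Among the measured compounds shown here, no measured compound has an aromatic ring there, so it is a weak guide. No step beyond the scatter is expected in this assay, in either direction, though the uncertainty is wide. The expected step is a 1.0-fold lower number from compound 2 to compound 3 (0.02 log units; within the scatter). For compound 3 the estimate is 11 mg/kg, with an expected range from 4 mg/kg to 30 mg/kg.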

Compound 3, dose for half-maximal effect: 100 mg/kg
Beside the measured number, compound 3's estimate is 9.1-fold (0.96 log units) below it, outside the stated range (above it).
By their numbers in this assay, from the lowest: compounds 2 and 1 (each within the scatter of the next); then compound 3.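

In this assay the group on the carbonyl carbon does matter: methyl(propyl)amino and morpholin-4-yl stood level, but (pyridin-3-yl)amino gives an 8.7-fold higher number from compound 2 to compound 3 (0.94 log units; beyond the scatter) and an 8.6-fold higher number from compound 1 to compound 3 (0.94 log units; beyond the scatter). Unlike morpholin-4-yl, the new group brings a six-membered aromatic ring and a hydrogen-bond donor, so two features change in one step, and more compound is needed for the effect. Nothing measured here gives a reason for this step.

The compounds shown leave open whether the aromatic ring, the hydrogen-bond donor or the ring nitrogen accounts for the step. A plain phenylamino group would test the ring nitrogen, and a methyl group on the amide nitrogen of (pyridin-3-yl)amino would replace the amide hydrogen while keeping the ring.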